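Replacing 2-cyanophenyl with 4-bromophenyl in compound 4

The source may report more compounds than this note shows. Statements on the series, on what has been measured and on what is new or still open speak of the compounds shown alone.

Compound 1 `N#Cc1ccccc1-n1cc(COc2cccc(NC(=O)Nc3ccc(Cl)c(C(F)(F)F)c3)c2)nn1` was tested in a functional assay on HepG2 cells (Homo sapiens) for inhibition, read by MTT assay, with a stated time of 72 h (a lower number here means a stronger inhibitor, a higher number a weaker inhibitor), where compound 1 gives 1970 nM, the second highest of three numbers. Compound 2 `O=C(Nc1cccc(OCc2cn(-c3ccc(Cl)cc3)nn2)c1)Nc1ccc(Cl)c(C(F)(F)F)c1` gives 2490 nM in this assay, and compound 3 `O=C(Nc1cccc(OCc2cn(-c3cccc(Br)c3)nn2)c1)Nc1ccc(Cl)c(C(F)(F)F)c1` gives 1040 nM. Compound 4 `O=C(Nc1cccc(OCc2cn(-c3ccc(Br)cc3)nn2)c1)Nc1ccc(Cl)c(C(F)(F)F)c1` differs from compound 1 in one place: 4-bromophenyl in place of 2-cyanophenyl on an aromatic nitrogen. Going by the values given here, two measured steps bear on this change: a 1.3-fold higher number from compound 1 to compound 2 (0.10 log units; within the scatter), and a 1.9-fold lower number from compound 1 to compound 3 (0.28 log units; within the scatter). Between the halogen-bearing analogues, a 2.4-fold lower number from compound 2 to compound 3 (0.38 log units; beyond the scatter). Because compound 2 gives 2490 nM and the step of a 1.3-fold higher number from compound 1 to compound 2 (0.10 log units; within the scatter) stayed within the scatter, compound 4 is expected to show no step beyond the scatter in this assay, a 1.0-fold higher number from compound 1 to compound 4 (0.01 log units; within the scatter). Compound 4 is therefore estimated at 2000 nM, with a range from 900 nM to 4500 nM.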

Compound 4, half-maximal inhibitory concentration: 2730 nM
Compound 4: middle estimate off by 1.4-fold (0.14 log units), on the low side, within the range that was stated.
By their numbers in this assay, from the lowest: compounds 3, 1, 2 and 4 (each within the scatter of the next, the first and the last beyond it).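

In this assay, 4-bromophenyl in place of 3-bromophenyl gives a 2.6-fold higher number from compound 3 to compound 4 (0.42 log units; beyond the scatter), so the two bromophenyl isomers on this aromatic nitrogen are separated by a modest step. Bromo in place of chloro gives a 1.1-fold higher number from compound 2 to compound 4 (0.04 log units; within the scatter), and 4-bromophenyl in place of 2-cyanophenyl gives a 1.4-fold higher number from compound 1 to compound 4 (0.14 log units; within the scatter), so neither of these changes separates its pair. No evidence is available on what lies behind these steps.

From the compounds shown here alone, whether a 3-chlorophenyl group would match 3-bromophenyl remains open. So does the effect of an aminophenyl or a carboxyphenyl group at this position.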